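Working notes: from compound 1 to compound 4

This account rests on a few compounds, and the source may have more. Where it says the series, first, only, none or still open, it means among the compounds named here.

Values in a functional assay on NCI/ADR-RES cells (Homo sapiens) for inhibition, read by sulforhodamine B assay, with a stated time of 48 h (a lower number here means a stronger inhibitor of growth, a higher number a weaker inhibitor of growth), so far:
- compound 1 (`Clc1ccc(Cn2cc(CCCOc3cccc4cccnc34)nn2)cc1`): 11.6 ug/mL
- compound 2 (`Brc1ccc(Cn2cc(CCCOc3cccc4cccnc34)nn2)cc1`): 25.8 ug/mL
- compound 3 (`FC(F)(F)Oc1ccc(Cn2cc(CCCOc3cccc4cccnc34)nn2)cc1`): 5.5 ug/mL

Of these three numbers, compound 1 stands second highest. Compound 4 (`Clc1cc(Cl)c(Cn2cc(CCCOc3cccc4cccnc34)nn2)c(Cl)c1`) is still unmeasured and differs from compound 1 in one place (2,4,6-trichlorophenyl in place of 4-chlorophenyl on a saturated chain carbon bound to an aromatic nitrogen), with 2,4,6-trichlorophenyl in place of 4-chlorophenyl on a saturated chain carbon bound to an aromatic nitrogen.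

The closest evidence is two single replacements of chloro on an aromatic carbon, bromo (a 2.2-fold higher number from compound 1 to compound 2 (0.35 log units; beyond the scatter)) and trifluoromethoxy (a 2.1-fold lower number from compound 1 to compound 3 (0.32 log units; beyond the scatter)). Both are modest and beyond the scatter, but they run in opposite directions. Among the compounds with values here, the widest step so far is also modest (a 4.7-fold lower number from compound 2 to compound 3 (0.67 log units; beyond the scatter)). Within the data shown here, no measured compound carries added chloro groups, so the data set no direction for this change, and no step beyond the scatter is expected in this assay.

The expected step is small (a 1.2-fold lower number from compound 1 to compound 4 (0.06 log units; within the scatter)) and uncertain. For compound 4 the estimated value is 10 ug/mL within an expected range of 4 ug/mL to 28 ug/mL in this series.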

Compound 4, concentration for 50% growth inhibition: 2.8 ug/mL
The estimate for compound 4 lay 3.6-fold (0.55 log units) above the measured number; the measured number lies below the stated range.
By their numbers in this assay, from the lowest: compounds 4 and 3 (each within the scatter of the next); then compound 1; then compound 2.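

In this assay, within the data shown here, the group on a saturated chain carbon bound to an aromatic nitrogen responds to added chloro groups: 2,4,6-trichlorophenyl in place of 4-chlorophenyl gives a 4.1-fold lower number from compound 1 to compound 4 (0.62 log units; beyond the scatter) and in place of 4-bromophenyl gives a 9.2-fold lower number from compound 2 to compound 4 (0.96 log units; beyond the scatter) as the widest step so far. The single replacements of chloro set no direction for this change, whereas both new steps run towards lower numbers and place compound 4 within the scatter of compound 3. No measured property of these groups is on hand to account for the steps.

The compounds shown leave open whether all three chloro groups are needed for the step. From the compounds shown here alone, how an amine or a carboxylic acid on the same ring would read in this assay also stays open.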